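The source may report more compounds than this note shows. Statements on the series, on what has been measured and on what is new or still open speak of the compounds shown alone.

Measured in a functional assay on A-375 cells (Homo sapiens) for antiproliferative activity, read by MTT assay, with a stated time of 72 h; on this read-out lower numbers stand for stronger inhibition and higher numbers for weaker inhibition:
- Compound 1 `COc1ncc(-c2ccc3c(c2)N(c2ccc(F)cc2)C(=O)CO3)cc1NS(=O)(=O)c1ccc(F)cc1`: > 40000 nM, a limit.
- Compound 2 `O=C1COc2ccc(-c3cnc(Cl)c(NS(=O)(=O)c4ccc(F)cc4)c3)cc2N1c1ccc(F)cc1`: > 40000 nM, a limit.
- Compound 3 `O=C1COc2ccc(-c3cccc(NS(=O)(=O)c4ccc(F)cc4)c3)cc2N1c1ccc(Cl)cc1`: 32500 nM.

Compound 1 stands at the limit of > 40000 nM in this assay, at which 2 of the 3 values shown sit, so only a limit is known for it and no number.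

Compound 4 `COc1ncc(-c2ccc3c(c2)N(c2ccc(Cl)cc2)C(=O)CO3)cc1NS(=O)(=O)c1ccc(F)cc1` differs from compound 1 by one exchange, chloro in place of fluoro on an aromatic carbon, which turns 4-fluorophenyl into 4-chlorophenyl: chloro in place of fluoro on an aromatic carbon.

For the measured compounds named here, the only measured step, a step that the two limits leave unreadable from compound 1 to compound 2, is a change at another place, and its size cannot be read. It therefore gives no size to carry over. Going by the values given here, compound 3 also carries the 4-chlorophenyl group but differs elsewhere as well, and it gives 32500 nM, the only number in the set.

The expectation is therefore a small step, if any, towards stronger inhibition, with compound 4 staying close to the limit. The expected change is an at least 1.1-fold lower number from compound 1 to compound 4 (0.05 log units; that floor lies within the scatter). For compound 4 the estimate is 35000 nM, with an expected range of 12000 nM to 60000 nM.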

Compound 4, half-maximal inhibitory concentration: 24100 nM
Compound 4: the middle estimate sits 1.5-fold (0.16 log units) above what was measured; the range from low to high includes it.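

In this assay, for the compounds shown here, 4-chlorophenyl in place of 4-fluorophenyl gives the first step in this set with a readable direction: an at least 1.6-fold lower number from compound 1 to compound 4 (0.22 log units; that floor lies within the scatter). The floor of that step lies within the usual scatter, so a real gain from this exchange is not established, although compound 4 gives a number at this position of the shared core. Compound 1 carries only a limit, so the step has a floor and no upper size: the limit of > 40000 nM in this assay, at which 2 of the 4 values shown sit.

As far as these compounds go, the step with chloro in place of methoxy cannot be read, both of its ends being limits, and the effect of that exchange stays open. Also open, from the compounds shown here alone, is whether bromo, methyl, trifluoromethyl or an amine at this position of the phenyl ring would move the series well clear of the limit in this assay.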